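A few compounds are considered here, and "the series" means these few. Any claim that something is new, unique, unknown or untested is made for them only; others in the source may bear on it.

Measured so far:
Compound 1 `Nc1cc(N)c2nc(-c3ccccc3)c(Sc3ccc(F)cc3)nc2c1` gives 45700 nM in a functional assay on OVCAR-5 cells (Homo sapiens) for inhibition, read by sulforhodamine B assay, with a stated time of 48 h; a higher number here means a weaker inhibitor of growth, a lower number a stronger inhibitor of growth.
Compound 2 `COc1cc(CNc2nc3cc(N)cc(N)c3nc2-c2ccccc2)cc(OC)c1OC` is reported in this assay only as a limit, < 50200 nM.

For the measured compounds named here, compound 1 stands on the only plain number given. Compound 2 sits at the limit of < 50200 nM in this assay, at which 1 of the 2 values shown sits. Compound 3 `Nc1cc(N)c2nc(-c3ccccc3)c(NCc3ccc(F)cc3)nc2c1` differs from compound 1 in one place: (4-fluorobenzyl)amino in place of (4-fluorophenyl)sulfanyl on an aromatic carbon. No step between measured compounds is shown, so nothing here points to a direction; the step expected in this assay, a 1.4-fold lower number from compound 1 to compound 3 (0.15 log units; within the scatter), is small, within the usual scatter. Compound 3 is therefore estimated at 32000 nM, with a range from 8000 nM to 110000 nM.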

Compound 3, concentration for total growth inhibition: 7590 nM
Estimate against measurement, compound 3: 4.2-fold (0.62 log units) above, outside the stated range (below it).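

In this assay this position responds to the change of group: (4-fluorobenzyl)amino in place of (4-fluorophenyl)sulfanyl gives a 6.0-fold lower number from compound 1 to compound 3 (0.78 log units; beyond the scatter) on an otherwise unchanged core. The fluorinated carbon ring stays, while the swap adds a hydrogen-bond donor and one heavy atom, and a single step cannot separate these differences. Nothing shown here accounts for the lower number. Still open, from the compounds shown here alone, is whether an ether oxygen in place of the amine nitrogen, or a longer chain between nitrogen and ring, would keep this step.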